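Methylating the hydroxy group of compound 3

The source may report more compounds than this note shows. Statements on the series, on what has been measured and on what is new or still open speak of the compounds shown alone.

In a functional assay on HT-29 cells (Homo sapiens) for inhibition, read by sulforhodamine B assay, with a stated time of 48 h (on this read-out lower numbers stand for stronger inhibition of growth and higher numbers for weaker inhibition of growth), compound 1 `CC1(/C=C/c2ccccc2)C=CC(=O)O1` gives 123000 nM, compound 2 `COc1ccc(/C=C/C2(C)C=CC(=O)O2)c(OC)c1` gives 57500 nM and compound 3 `CC1(/C=C/c2ccccc2O)C=CC(=O)O1` gives 31300 nM. Compound 3 thus sits at the low end of the three numbers, within the scatter of compound 2 and beyond the scatter from compound 1.

The next structure is compound 4 `COc1ccccc1/C=C/C1(C)C=CC(=O)O1`. Its change from compound 3 is methyl in place of hydrogen on an oxygen on an aromatic ring, that is, hydroxy to methoxy. Among the measured compounds shown here, one measured step bears directly on this hydroxy: a 3.9-fold lower number from compound 1 to compound 3 (0.59 log units; beyond the scatter), a modest change beyond the scatter. For the measured compounds named here, no measured pair isolates methoxy against hydroxy. Going by the values given here, compound 2, the only measured compound carrying methoxy, stands at 57500 nM, so a small upward move is expected, giving back part of that step. The expected change is a 1.8-fold higher number from compound 3 to compound 4 (0.24 log units; within the scatter), which may not clear the scatter. For compound 4 the estimated value is 55000 nM, with an expected range of 25000 nM to 120000 nM.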

Compound 4, concentration for total growth inhibition: 30800 nM
Estimate against measurement, compound 4: 1.8-fold (0.25 log units) above; measured number inside the range.
By their numbers in this assay, from the lowest: compounds 4, 3 and 2 (each within the scatter of the next); then compound 1.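

In this assay the hydrogen on this oxygen can be replaced by methyl with no change beyond the scatter (a 1.0-fold lower number from compound 3 to compound 4 (0.01 log units; within the scatter)), so the free hydroxy is not required here. Methoxy in place of hydrogen on the aromatic carbon gives a step beyond the scatter (a 4.0-fold lower number from compound 1 to compound 4 (0.60 log units; beyond the scatter)) of a size close to that of hydroxy (a 3.9-fold lower number from compound 1 to compound 3 (0.59 log units; beyond the scatter)), while hydrogen in place of the further methoxy of compound 2 stays within the scatter (a 1.9-fold lower number from compound 2 to compound 4 (0.27 log units; within the scatter)). Nothing measured on these compounds accounts for this tolerance.

Open, from the compounds shown here alone, is whether a longer chain on this oxygen, such as ethyl or benzyl, would keep the number in the same range. Also open, going by these compounds, is whether an amine or a fluorine in place of the hydroxy would match the step seen for hydroxy and methoxy.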